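The source may hold more compounds than are shown below. What is called first, only, known or untested is meant among the compounds shown, and "the series" means these compounds.

Of the compounds shown here, two sharing one core have been tested in a functional assay on PC-3 cells (Homo sapiens) for inhibition, read by sulforhodamine B assay, with a stated time of 72 h; on this read-out higher numbers stand for weaker inhibition and lower numbers for stronger inhibition. Compound 1 `Nc1sc(-c2ccc(Cl)cc2)c(-c2ccc(Cl)cc2)c1C(=O)N1CCOCC1`, with morpholin-4-yl on the carbonyl carbon, gives 11700 nM. Compound 2 `COc1ccc(CNC(=O)c2c(N)sc(-c3ccc(Cl)cc3)c2-c2ccc(Cl)cc2)cc1` gives 29500 nM, the higher of the two numbers and therefore the weaker inhibition of the pair. Compound 3 `Nc1sc(-c2ccc(Cl)cc2)c(-c2ccc(Cl)cc2)c1C(=O)NC1CC1` has not yet been measured. It differs from compound 2 in one place, on an amide-type nitrogen: cyclopropyl in place of 4-methoxybenzyl on an amide-type nitrogen. In short, cyclopropyl stands in place of 4-methoxybenzyl.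

Among the measured compounds shown here, only one measured step bears on this change: a 2.5-fold higher number from compound 1 to compound 2 (0.40 log units; beyond the scatter). That modest step came with (4-methoxybenzyl)amino in place of morpholin-4-yl on a carbonyl carbon. Compound 3 loses the same 4-methoxybenzyl group, but cyclopropyl itself has not been tested, and a single step is thin evidence. A small move towards a lower number is therefore expected, no larger than the measured step. The expected change is a 1.7-fold lower number from compound 2 to compound 3 (0.24 log units; within the scatter). Compound 3 is estimated at 17000 nM, with an expected range from 7000 nM to 42000 nM.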

Compound 3, half-maximal inhibitory concentration: 3680 nM
Compound 3: middle estimate off by 4.6-fold (0.66 log units), on the high side; measured number outside the range, below it.
By their numbers in this assay, from the lowest: compound 3; then compound 1; then compound 2.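

In this assay, among the compounds shown here, cyclopropyl in place of 4-methoxybenzyl on the amide-type nitrogen gives an 8.0-fold lower number from compound 2 to compound 3 (0.90 log units; beyond the scatter), a clearly larger move than the single earlier step at this carbonyl could show. For the compounds shown here, that earlier step showed only that one group on the carbonyl carbon gave a higher number than morpholin-4-yl, whereas cyclopropylamino in place of morpholin-4-yl gives a 3.2-fold lower number from compound 1 to compound 3 (0.50 log units; beyond the scatter), so this position can also move below the morpholine amide. Nothing measured on these compounds explains the size of either step.

The compounds shown leave open whether the lower number belongs to the three-membered ring itself or simply comes with a group of 3 heavy atoms replacing one of 9 on this nitrogen, a question that an open-chain propyl group or a cyclobutyl ring could help to separate. They also leave open what part of 4-methoxybenzyl goes with its higher number, which a plain benzyl group, lacking the methoxy, could begin to answer.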